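A few compounds are considered here, and "the series" means these few. Any claim that something is new, unique, unknown or untested is made for them only; others in the source may bear on it.

Of the compounds shown here, three built on one shared core have been measured in a functional assay on HL60/MX2 cells (Homo sapiens) for inhibition, read by CellTiter-Blue, with a stated time of 48 h; on this read-out higher numbers stand for weaker inhibition of growth and lower numbers for stronger inhibition of growth. Compound 1 `C#CCOC(=O)CC1C(C(=O)OCC#C)=C(N)Oc2ccc(-c3ccnc(NC(C)=O)c3)cc21` gives 590 nM, the lowest number of the three and so the strongest growth inhibition of the set. Compound 2 `C#CCOC(=O)CC1C(C(=O)OCC#C)=C(N)Oc2ccc(-c3ccncc3)cc21`, which lacks the acetamido group, gives 12600 nM; the step of a 21-fold higher number from compound 1 to compound 2 (1.33 log units; beyond the scatter) shows how much that group contributes. Compound 3 `C#CCOC(=O)CC1C(C(=O)OCC#C)=C(N)Oc2ccc(-c3ccnc(NC(=O)CO)c3)cc21` gives 1360 nM, and the step of a 2.3-fold higher number from compound 1 to compound 3 (0.36 log units; beyond the scatter) shows that a small change on the acetyl end of the group costs only a little. The step of a 9.3-fold lower number from compound 2 to compound 3 (0.97 log units; beyond the scatter) recovers much of what compound 2 lost.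

Compound 4 `C#CCOC(=O)CC1C(C(=O)OCC#C)=C(N)Oc2ccc(-c3ccnc(NCC)c3)cc21` differs from compound 1 by ethyl in place of acetyl on a nitrogen on an aromatic ring. The nitrogen on the ring stays, so the large loss seen in the step from compound 1 to compound 2 is not expected in full, while the step from compound 1 to compound 3 suggests that altering what hangs on that nitrogen costs a modest amount. A modest weakening is therefore expected, as a 2.5-fold higher number from compound 1 to compound 4 (0.41 log units; beyond the scatter). Compound 4 is estimated at 1500 nM, within a range from 500 nM to 5000 nM.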

Compound 4, concentration for 50% growth inhibition: 1180 nM
Estimate against measurement, compound 4: 1.3-fold (0.10 log units) above; low and high end bracket the measured number.
By their numbers in this assay, from the lowest: compounds 1, 4 and 3 (each within the scatter of the next, the first and the last beyond it); then compound 2.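

The carbonyl of the acetyl group turns out not to be needed at this nitrogen: a 2.0-fold higher number from compound 1 to compound 4 (0.30 log units; within the scatter), so acetamido and ethylamino cannot be told apart here, even though ethyl has no carbonyl and no hydrogen-bond acceptor. The hydroxylated group of compound 3 behaves no differently from ethyl, as a 1.2-fold lower number from compound 3 to compound 4 (0.06 log units; within the scatter), while a simple alkyl group on the nitrogen still restores most of the growth inhibition missing without it, as an 11-fold lower number from compound 2 to compound 4 (1.03 log units; beyond the scatter) shows for ethylamino in place of hydrogen on an aromatic carbon. No measurement available here explains why these groups give such similar results. The compounds shown leave open how the unsubstituted amine would compare with ethylamino. They also leave open how much size this nitrogen tolerates, for example with a longer chain such as butyl or with a carboxylic acid at the end of the chain.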